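Isopropyl for Cyano on an Oxime Ether Pair

The source may report more compounds than this note shows. Statements on the series, on what has been measured and on what is new or still open speak of the compounds shown alone.

Of the compounds shown here, three have numbers so far in an assay on HepG2 cells for agonist activity at nuclear receptor subfamily 1 group I member 3 (Homo sapiens), read by a luciferase reporter, with a stated time of 23 h; on this read-out higher numbers stand for an effect only at larger amounts of compound and lower numbers for an effect already at smaller amounts. Compound 1 `COc1ccc(CO/N=C/c2c(-c3ccc4ccccc4c3)nc3occn23)cc1` gives 4400 nM. Compound 2 `N#Cc1ccc(-c2nc3sccn3c2/C=N/OCc2ccc(Cl)c(Cl)c2)cc1` gives 3400 nM in this assay. Compound 3 `Clc1ccc(-c2nc3occn3c2/C=N/OCc2ccc(Cl)c(Cl)c2)cc1` gives 410 nM in this assay. Compound 2 thus holds the second highest of the three numbers; compound 1 sits within the usual scatter of it, so the two cannot be told apart, while compound 3 lies beyond the scatter at a lower number. Within the data shown here, compound 3 and compound 2 differ in more than one place, so no single step connects them and nothing can be read from that gap about any one change.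

Compound 4 `CC(C)c1ccc(-c2nc3sccn3c2/C=N/OCc2ccc(Cl)c(Cl)c2)cc1` differs from compound 2 in one place: isopropyl in place of cyano on an aromatic carbon. Among the measured compounds shown here, no measured pair in this set shows that same change, so the expectation rests on compound 2 alone. Compound 4 is expected to give 1500 nM, between 500 nM and 5000 nM. The step of a 2.3-fold lower number from compound 2 to compound 4 (0.36 log units; beyond the scatter) is expected to be a modest move toward a lower number, close to the edge of the scatter rather than far beyond it.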

Compound 4, half-maximal effective concentration: 590 nM
Compound 4: middle estimate off by 2.5-fold (0.41 log units), on the high side; low and high end bracket the measured number.
By their numbers in this assay, from the lowest: compounds 3 and 4 (each within the scatter of the next); then compounds 2 and 1 (each within the scatter of the next).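

In this assay, among these compounds, the change from 4-cyanophenyl to 4-isopropylphenyl gives a 5.8-fold lower number from compound 2 to compound 4 (0.76 log units; beyond the scatter) and is the first single-place step in this set. It shows that the group on this aromatic carbon, para to a large group, can shift the number beyond the scatter while the rest of compound 2 stays the same. The cyano brings a hydrogen-bond acceptor and the isopropyl none, but nothing available ties the step to that count or to any other difference between the two groups.

As far as these compounds go, whether an amine or a carboxylic acid on this carbon would move the number the same way remains open. From the compounds shown here alone, it is also open whether isopropyl in place of cyano would give a similar step on the core of compound 3.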